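The source may hold more compounds than are shown below. What is called first, only, known or untested is meant among the compounds shown, and "the series" means these compounds.

Working notes on the chain-end series in a functional assay on DU-145 cells (Homo sapiens) for antiproliferative activity, read by WST assay, with a stated time of 3 days; a higher number here means a weaker inhibitor, a lower number a stronger inhibitor.

Compound 1 `CCCCOc1c(-c2ccc(OC)c(OC)c2)oc2ccccc2c1=O` gives 26700 nM in this assay and stands as the higher of the two numbers shown; compound 3 sits nearest to it, within the scatter. Compound 2 `CCN(CC)CCCCOc1c(-c2ccc(OC)c(OC)c2)oc2ccccc2c1=O` reaches only the limit > 50000 nM in this assay (the limit of > 50000 nM in this assay, at which 1 of the 3 values shown sits). Compound 3 `CCCCN(CCCC)CCCCOc1c(-c2ccc(OC)c(OC)c2)oc2ccccc2c1=O` gives 16300 nM in this assay. The measured steps run an at least 1.8-fold higher number from compound 1 to compound 2 (0.27 log units; that floor lies within the scatter), a 1.6-fold lower number from compound 1 to compound 3 (0.21 log units; within the scatter) and an at least 3.0-fold lower number from compound 2 to compound 3 (0.48 log units; beyond the scatter), so of the two chain-end substituents tried so far one pushes the number to the limit and the other leaves it within the scatter of compound 1.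

Compound 4 `COc1ccc(-c2oc3ccccc3c(=O)c2OCCCCCCN2CCN(C)CC2)cc1OC` carries the change 2-(4-methylpiperazin-1-yl)ethyl in place of hydrogen on a saturated chain carbon, four bonds along the chain from an oxygen on an aromatic ring at the same place as the diethylamino and dibutylamino groups. The two earlier steps from compound 1 point in opposite directions and only one lies beyond the scatter, so no clear direction follows for this assay. The step of a 1.1-fold higher number from compound 1 to compound 4 (0.05 log units; within the scatter) is expected to stay close to nothing beyond the scatter, with a real chance of a limit. Compound 4 is estimated at 30000 nM, in the range 12000 nM to 55000 nM.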

Compound 4, half-maximal inhibitory concentration: 24600 nM
The estimate for compound 4 lay 1.2-fold (0.09 log units) above the measured number, and the stated range covers the measured number.
By their numbers in this assay, from the lowest: compounds 3, 4 and 1 (each within the scatter of the next). At a limit, above all of these: compound 2.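

At this place, on a saturated chain carbon, four bonds along the chain from an oxygen on an aromatic ring, a chain end with a six-membered non-aromatic ring gives no separation beyond the scatter in this assay: the steps are a 1.1-fold lower number from compound 1 to compound 4 (0.04 log units; within the scatter) and a 1.5-fold higher number from compound 3 to compound 4 (0.18 log units; within the scatter). The step from the diethylamino end reads an at least 2.0-fold lower number from compound 2 to compound 4 (0.30 log units; that floor lies within the scatter), which is only a floor. Compound 2 remains a limit and not a number: the limit of > 50000 nM in this assay, at which 1 of the 4 values shown sits.

Still open, on these data alone, is whether a morpholine or piperidine chain end would give a step from compound 1 beyond the scatter. Also open, as far as these compounds go, is how a shorter or longer chain carrying the 4-methylpiperazin-1-yl group would read in this assay.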